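Swapping the Aryl Ring for Pyridine in Compound 4

The source may report more compounds than this note shows. Statements on the series, on what has been measured and on what is new or still open speak of the compounds shown alone.

Of the compounds shown here, three built on one shared core have been measured in an ADME assay on HEK293 cells (Homo sapiens) for cytotoxicity, read by MTT assay, with a stated time of 48 h; a higher number here means a weaker inhibitor, a lower number a stronger inhibitor. Compound 1 `COc1ccc(/C=C2/S/C(=N/c3ccccc3)N(Cc3ccncc3)C2=O)cc1` gives 47900 nM, the second highest of the three numbers. Compound 2 `O=C1/C(=C\c2ccc(Cl)cc2)S/C(=N/c2ccccc2)N1Cc1ccncc1` gives 42300 nM, and the step of a 1.1-fold lower number from compound 1 to compound 2 (0.05 log units; within the scatter) stays within the scatter. Compound 3 `CC(C)c1ccc(/C=C2/S/C(=N/c3ccccc3)N(Cc3ccncc3)C2=O)cc1` gives 137000 nM, reached through the step of a 2.9-fold higher number from compound 1 to compound 3 (0.46 log units; beyond the scatter), while the step of a 3.2-fold higher number from compound 2 to compound 3 (0.51 log units; beyond the scatter) is of similar size. The unmeasured compound 4 `O=C1/C(=C\c2ccccn2)S/C(=N/c2ccccc2)N1Cc1ccncc1` differs from compound 1 in one place: pyridin-2-yl in place of 4-methoxyphenyl on a double-bonded chain carbon bound to a double-bonded ring carbon. Among the measured compounds shown here, the measured steps each alter only a substituent on the same aromatic ring; none exchanges the ring itself, so no step bears directly on this change. Those substituent changes gave at most a modest shift, and the three numbers span only a modest range. For compound 4 a step no larger than the scatter is therefore expected, a 1.0-fold higher number from compound 1 to compound 4 (0.02 log units; within the scatter). Compound 4 is thus estimated at 50000 nM, within a range from 20000 nM to 125000 nM.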

Compound 4, half-maximal inhibitory concentration: 161000 nM
Compound 4: the middle estimate sits 3.2-fold (0.51 log units) below what was measured; measured number outside the range, above it.
By their numbers in this assay, from the lowest: compounds 2 and 1 (each within the scatter of the next); then compounds 3 and 4 (each within the scatter of the next).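

Exchanging the whole aromatic ring at this position, rather than only a substituent on it, can also shift the number in this assay: pyridin-2-yl in place of 4-methoxyphenyl gives a 3.4-fold higher number from compound 1 to compound 4 (0.53 log units; beyond the scatter), and in place of 4-chlorophenyl it gives a 3.8-fold higher number from compound 2 to compound 4 (0.58 log units; beyond the scatter). In place of 4-isopropylphenyl, the same exchange gives a 1.2-fold higher number from compound 3 to compound 4 (0.07 log units; within the scatter), so these two different groups give numbers that cannot be told apart here, and a higher number at this position is not tied to one kind of ring. No measurement shown explains these steps.

Still open, from the compounds shown here alone, is whether the ring nitrogen or the loss of the substituent on the ring drives the change. A plain phenyl group and a pyridin-4-yl group at the same place would help separate those two possibilities.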